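A few compounds are considered here, and "the series" means these few. Any claim that something is new, unique, unknown or untested is made for them only; others in the source may bear on it.

Working notes on the series.

Of the compounds shown here, two carry numbers so far. Compound 1 `COc1ccc(-c2nc(C)c(C(=O)CSc3nc(N)c(C#N)c(-c4ccc(OC)cc4)n3)s2)cc1` in a functional assay on U-87MG ATCC cells for antiproliferative activity against U-87 MG (Homo sapiens), read by MTT assay, with a stated time of 48 h, tested at 5 uM (a lower number here means a stronger effect, a higher number a weaker effect of the compound at the concentration tested), gives 35.6%. Within the data shown here, compound 2 `COc1ccc(-c2nc(SCC(=O)c3sc(-c4ccc(Cl)cc4)nc3C)nc(N)c2C#N)cc1` in this assay gives 69.7%, which is the higher of the two numbers, the weaker effect; the only measured step, a number 34.1 percentage points higher from compound 1 to compound 2 (beyond the scatter), separates them.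

Compound 3 `Cc1nc(-c2ccc(Cl)cc2)sc1C(=O)CSc1nc(N)c(C#N)c(-c2ccccc2)n1` is not yet measured. It differs from compound 2 by hydrogen in place of methoxy on an aromatic carbon; the same change, cut one bond further out, reads 4-methoxyphenyl to phenyl.

Among the measured compounds shown here, no measured step touches this position: the single step from compound 1 to compound 2 alters the aryl on the other side of the shared core, and its size, though large, says nothing about the methoxy removed here. The direction in this assay is therefore open, and a step within the scatter is as likely as one beyond it.

Compound 3 is expected to give 65%, with a range of 45% to 85%; the expected step is a number 4.7 percentage points lower from compound 2 to compound 3 (within the scatter).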

Compound 3, a percentage reported as activity, at one concentration (the size of the read-out at that concentration, not a potency): 71.1%
Compound 3: middle estimate off by 6.1 percentage points, on the low side; the range from low to high includes it.
By their numbers in this assay, from the lowest: compound 1; then compounds 2 and 3 (each within the scatter of the next).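

In this assay, hydrogen in place of methoxy on an aromatic carbon, para to a large group, gives a number 1.4 percentage points higher from compound 2 to compound 3 (within the scatter), so 4-methoxyphenyl and phenyl are not told apart at this position while the chloro stays on the other aryl. This change thus reads differently from the one on the other side of the shared core, which gives a number 34.1 percentage points higher from compound 1 to compound 2 (beyond the scatter). No measurement on hand bears on the reason for either result.

Going by these compounds, compounds 2 and 3 test only methoxy and hydrogen here, so it remains open whether an amine, a carboxylic acid or a longer alkoxy chain at the same place would read like them. On these data alone, it is also open whether removing the methoxy would read the same with methoxy rather than chloro on the other aryl.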